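A few compounds are considered here, and "the series" means these few. Any claim that something is new, unique, unknown or untested is made for them only; others in the source may bear on it.

Compound 1 `CC(=O)Oc1ccccc1C(=O)O[C@H]1CO[C@H]2[C@@H]1OC[C@H]2OC(=O)c1ccc(O)cc1` is measured in an ADME assay on a cell-free system (plasma, Homo sapiens) for metabolic stability, with Plasma (Rattus norvegicus) as the target, read by HPLC, at pH 7.4 (a lower number here means that the compound disappears faster, a higher number that the compound lasts longer), where compound 1 gives 0.0198 h. This sits level with compound 2 `CCCCC(=O)O[C@@H]1CO[C@H]2[C@@H]1OC[C@@H]2OC(=O)c1ccccc1OC(C)=O`, for which this assay returns 0.0198 h, so that no change at the digits printed from compound 1 to compound 2 (within the scatter); together the two stand as the lowest of the three numbers. Among the compounds with values here, compound 3 `CC(=O)Oc1ccccc1C(=O)O[C@H]1CO[C@H]2[C@@H]1OC[C@H]2OC(=O)CO[N+](=O)[O-]` lies furthest away, giving 0.06 h, and the step of a 3.0-fold higher number from compound 1 to compound 3 (0.48 log units; beyond the scatter) is the only change beyond the scatter in the set.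

Compound 4 `CC(=O)Oc1ccccc1C(=O)O[C@H]1CO[C@H]2[C@@H]1OC[C@H]2OC(=O)c1ccccc1CO[N+](=O)[O-]` is the next member to be measured. Relative to compound 1 the change is 2-((nitrooxy)methyl)phenyl in place of 4-hydroxyphenyl on a carbonyl carbon.

Within the data shown here, two measured steps bear on this. Replacing the 4-hydroxyphenyl with butyl gave no change at the digits printed from compound 1 to compound 2 (within the scatter), while replacing it with (nitrooxy)methyl gave a 3.0-fold higher number from compound 1 to compound 3 (0.48 log units; beyond the scatter). Compound 4 keeps an aromatic ring on that carbonyl carbon, as compound 1 does, and adds the nitrooxy group through a methylene on that ring rather than directly on the carbonyl. The expected step is therefore small, either no change beyond the scatter or a slight rise toward compound 3, and is estimated as a 1.5-fold higher number from compound 1 to compound 4 (0.18 log units; within the scatter). For compound 4 the half-life in this assay is estimated at 0.03 h, with a likely range from 0.015 h to 0.07 h.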

Compound 4, half-life: 0.045 h
Compound 4: middle estimate off by 1.5-fold (0.18 log units), on the low side, and the stated range covers the measured number.
By their numbers in this assay, from the lowest: compounds 1 and 2 (each within the scatter of the next); then compounds 4 and 3 (each within the scatter of the next).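

Within the data shown here, at this carbonyl carbon, 2-((nitrooxy)methyl)phenyl in this assay gives a 2.3-fold higher number from compound 1 to compound 4 (0.36 log units; beyond the scatter), and against the butyl ester it gives a 2.3-fold higher number from compound 2 to compound 4 (0.36 log units; beyond the scatter), so the higher number is no longer seen only with the short (nitrooxy)methyl group and now also appears with an aromatic ring in that place. Among these compounds, the two groups that carry nitrooxy cannot be told apart, with a 1.3-fold lower number from compound 3 to compound 4 (0.12 log units; within the scatter), and in these four compounds both stand above the two compounds without nitrooxy, with no compound going against that division. No measurement given here accounts for the rise or explains why the two nitrooxy groups read alike.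

As far as these compounds go, what remains open is whether the nitrooxy group itself goes with the higher number, since a plain phenyl or a 2-methylphenyl on the same carbonyl carbon would be needed to separate it from the rest of the new group. Also open, from the compounds shown here alone, is how far the number would move with a longer chain carrying the nitrooxy group, or with an amine or a carboxylic acid on the ring in its place.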